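Benzyl Analogue Weighed Against Two Non-Cytotoxic Relatives

This account rests on a few compounds, and the source may have more. Where it says the series, first, only, none or still open, it means among the compounds named here.

Compound 1, `COc1ccc(CNc2nc(SC)nc3ncccc23)cc1`: > 100000 nM
Compound 2, `CSc1nc(NCCCCCO)c2cccnc2n1`: > 100000 nM

In an ADME assay on BEAS-2B cells (Homo sapiens) for cytotoxicity, read by MTT assay, with a stated time of 72 h (on this read-out higher numbers stand for weaker inhibition of growth and lower numbers for stronger inhibition of growth), compound 1 gives only a limit, > 100000 nM. In this assay compound 2 likewise gives only a limit, > 100000 nM. Compound 2 therefore stands where every shown value stands: at the limit of > 100000 nM in this assay, at which 2 of the 2 values shown sit, so that no number separates it from compound 1 and nothing is known of any order between them.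

Compound 3, `CSc1nc(NCc2ccccc2)c2cccnc2n1`, has not been measured. It differs from compound 2 by phenyl in place of 4-hydroxybutyl on a saturated chain carbon bound to a nitrogen on an aromatic ring. No step between measured compounds is known in this assay, and both shown values sit at the limit, so for this change no step beyond the scatter is expected in either direction. Given that compound 2 shows > 100000 nM, compound 3 is expected to show a step of a number no higher from compound 2 to compound 3 (the limit leaves the size open) in this assay. The estimate for compound 3 in this assay is 100000 nM, with a range from 30000 nM to 300000 nM, and most likely the assay will again report only its limit.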

Compound 3, concentration for total growth inhibition: 61700 nM
Compound 3: middle estimate off by 1.6-fold (0.21 log units), on the high side; measured number inside the range.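

With phenyl in place of 4-hydroxybutyl on a saturated chain carbon bound to a nitrogen on an aromatic ring, this assay gives compound 3 a measured number rather than a limit, and the change amounts to an at least 1.6-fold lower number from compound 2 to compound 3 (0.20 log units; that floor lies within the scatter). The phenyl ring alone does not account for that number, since the methoxy group also matters to the read-out: hydrogen in place of methoxy on an aromatic carbon gives an at least 1.6-fold lower number from compound 1 to compound 3 (0.20 log units; that floor lies within the scatter). Both steps are floors that do not reach beyond the scatter, so neither change is shown to do more than bring a number into reach of the assay, and the true size of each stays unknown: the limit of > 100000 nM in this assay, at which 2 of the 3 values shown sit.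

The compounds shown leave open how far the number would move with an amine or a carboxylic acid at the end of the chain in place of the hydroxyl, or with a longer chain between the nitrogen and the phenyl ring. They also leave open whether a chlorine or a fluorine on the phenyl ring would behave like hydrogen or like methoxy.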